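The source may report more compounds than this note shows. Statements on the series, on what has been measured and on what is new or still open speak of the compounds shown alone.

In a functional assay on A549 cells (Homo sapiens) for inhibition, read by sulforhodamine B assay, with a stated time of 48 h, tested at 50 uM (a higher number here means more inhibition of growth at the concentration tested, a lower number less inhibition of growth), compound 1 `CCCOc1ccc([C@@H]2CC(=O)c3cc(CC=C(C)C)c(OC)cc3O2)cc1` gives 43%. Among the compounds with values here, the only other compound measured here is compound 2 `COc1ccc([C@@H]2C/C(=N/OCc3cn(-c4ccc(O)cc4)nn3)c3cc(CC=C(C)C)c(OC)cc3O2)cc1`, which in this assay gives 52%; the two numbers lie within the usual scatter of each other, so neither stands apart, and compound 1 simply has the lower of the two figures. The two structures differ in several places at once, so their values say nothing about any single change. Compound 3 `COc1cc2c(cc1CC=C(C)C)C(=O)C[C@@H](c1ccc(Oc3ccccc3)cc1)O2` differs from compound 1 in one place: phenyl in place of propyl on an oxygen on an aromatic ring. Within the data shown here, no measured pair shows what this change does, so the expectation rests on compound 1 alone. The step of a number 2 percentage points higher from compound 1 to compound 3 (within the scatter) is expected to be small, with no direction beyond the scatter. Compound 3 is estimated to give 45% in this assay, with a range from 25% to 65%.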

Compound 3, percent growth inhibition at one concentration: 46%
Compound 3: the middle estimate sits 1 percentage points below what was measured; measured number inside the range.
By their numbers in this assay, from the lowest: compounds 1, 3 and 2 (each within the scatter of the next).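

In this assay, within the data shown here, phenyl in place of propyl on an oxygen on an aromatic ring gives a number 3 percentage points higher from compound 1 to compound 3 (within the scatter), the first reading of a single change at this position. At this concentration, then, the propoxy and phenoxy compounds cannot be told apart, even though the entering group brings a ring and more heavy atoms than the propyl it replaces. Nothing available bears on why the two groups read alike.

From the compounds shown here alone, whether another group at this oxygen would shift the number beyond the scatter remains open, for instance a longer chain such as hexyl, a chain ending in an amine, or a phenyl ring carrying a carboxylic acid. Going by these compounds, it is also open whether compound 1 and compound 3 would stay this close at other concentrations.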